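The compounds below may be only part of what the source reports. "The series", "measured", "known", "first", "only" and "open" are said of these compounds alone.

Measured compounds:
- compound 1 `COc1ccc(C2Cc3ccccc3C(C3=C(O)OC(C)(c4ccccc4)CC3=O)C2)cc1`: in a functional assay on SK-MEL-2 cells (Homo sapiens) for inhibition, with a stated time of 72 h (on this read-out lower numbers stand for stronger inhibition and higher numbers for weaker inhibition), compound 1 gives > 10000 nM, a limit of the assay
- compound 2 `CCC1(c2ccccc2)CC(=O)C(C2CC(c3ccc(OCc4ccc(C(F)(F)F)cc4)cc3)Cc3ccccc32)=C(O)O1`: in this assay compound 2 gives > 10000 nM, likewise a limit

Compound 2 therefore stands at the limit, as the limit of > 10000 nM in this assay, at which 2 of the 2 values shown sit, shows. Compound 3 `CCC1(c2ccccc2)CC(=O)C(C2CC(c3ccc(OC)cc3)Cc3ccccc32)=C(O)O1` differs from it by hydrogen in place of 4-(trifluoromethyl)phenyl on a saturated chain carbon bound to an oxygen on an aromatic ring, which leaves a methoxy group as in compound 1. For the measured compounds named here, no step between measured compounds is available to size this change. Compound 3 is expected to stay at the limit, giving a step that the limit leaves unreadable from compound 2 to compound 3 of no size beyond the scatter. The estimate for compound 3 is 20000 nM, between 5000 nM and 80000 nM.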

Compound 3, half-maximal inhibitory concentration: > 10000 nM
Compound 3: no number, only a limit (the forecaster's own chance of this, stated with the estimate: 75%); the middle value lies beyond the limit too.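

For the compounds shown here, no step among compound 1, compound 2 and compound 3 can be read, as all three stand at the same limit: the limit of > 10000 nM in this assay, at which 3 of the 3 values shown sit. Going by these compounds, whether changing (4-(trifluoromethyl)benzyl)oxy to methoxy, or adding the methyl, alters inhibition at all stays open.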